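The source may report more compounds than this note shows. Statements on the series, on what has been measured and on what is new or still open speak of the compounds shown alone.

Measured so far:
Compound 1 `CC/C(=C(/c1ccc(/C=C/C(=O)O)cc1)c1cc2ccccc2[nH]1)c1ccccc1C` gives 33 nM in a functional assay on MCF7 cells (Homo sapiens) for inhibition; on this read-out lower numbers stand for stronger inhibition and higher numbers for weaker inhibition.
Compound 2 `CC/C(=C(/c1ccc(/C=C/C(=O)O)cc1)c1cc2ccccc2[nH]1)c1ccc(F)cc1Cl` gives 39 nM in this assay.

Compound 2 holds the higher of the two numbers, and compound 1 sits nearest to it; the gap between them lies within the usual scatter, so neither can be called the stronger inhibitor. For the measured compounds named here, the one measured step that bears on the question is a 1.2-fold higher number from compound 1 to compound 2 (0.07 log units; within the scatter), which shows that replacing one aromatic ring with another at this chain position left the result essentially unchanged.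

Compound 3 `CC/C(=C(/c1ccc(/C=C/C(=O)O)cc1)c1cc2ccccc2[nH]1)c1ccc(Cl)c(C(F)(F)F)c1` has not yet been measured. Its difference from compound 2 is 4-chloro-3-(trifluoromethyl)phenyl in place of 2-chloro-4-fluorophenyl on a double-bonded chain carbon bound to a double-bonded chain carbon and a saturated chain carbon. Since the earlier exchange of rings at the same place moved the number so little, the step of a 1.2-fold higher number from compound 2 to compound 3 (0.06 log units; within the scatter) is expected to stay within the scatter as well, with no clear direction. On that basis compound 3 is estimated at 45 nM, within a range from 15 nM to 150 nM.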

Compound 3, half-maximal inhibitory concentration: 2200 nM
The estimate for compound 3 lay 49-fold (1.69 log units) below the measured number; the measured number lies above the stated range.
By their numbers in this assay, from the lowest: compounds 1 and 2 (each within the scatter of the next); then compound 3.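

The ring on this double-bonded chain carbon is not freely exchangeable: in this assay there is a 56-fold higher number from compound 2 to compound 3 (1.75 log units; beyond the scatter), and the comparison with the 2-methylphenyl compound agrees, with a 67-fold higher number from compound 1 to compound 3 (1.82 log units; beyond the scatter). The two earlier rings gave no sign of this, whereas 4-chloro-3-(trifluoromethyl)phenyl, with its larger count of heavy atoms, shows that inhibition can be weakened sharply by a change at this place. Nothing measured here explains the loss.

The new ring differs from both earlier rings in several features at once, so the compounds shown cannot separate the contribution of the trifluoromethyl group from that of the chlorine in its 4-position. As far as these compounds go, it also remains open how a ring with a methoxy group or a nitrile in place of the trifluoromethyl group would behave.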